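Ether substituent changes on the shared core

A few compounds are considered here, and "the series" means these few. Any claim that something is new, unique, unknown or untested is made for them only; others in the source may bear on it.

Within the data shown here, compound 2 `Cn1cc(-c2cc(C(C)(C)O)ccc2Oc2ccccc2)c2cc(C(=O)NCc3ccc(C(=O)Nc4ccccc4N)cc3)[nH]c2c1=O` holds the higher of the two numbers so far: in a functional assay on MV4-11 cells (Homo sapiens) for antiproliferative activity, read by CCK-8 assay, with a stated time of 72 h (a higher number here means a weaker inhibitor, a lower number a stronger inhibitor), compound 2 gives 100 nM. The comparison compound 1 `CC(C)Oc1ccc(C(C)(C)O)cc1-c1cn(C)c(=O)c2[nH]c(C(=O)NCc3ccc(C(=O)Nc4ccccc4N)cc3)cc12` is stronger here; in this assay compound 1 gives 40 nM. Among the measured compounds shown here, the only measured step, a 2.5-fold higher number from compound 1 to compound 2 (0.40 log units; beyond the scatter), concerns the same oxygen. Compound 3 `Cn1cc(-c2cc(C(C)(C)O)ccc2OC2CC2)c2cc(C(=O)NCc3ccc(C(=O)Nc4ccccc4N)cc3)[nH]c2c1=O` differs from compound 2 by cyclopropyl in place of phenyl on an oxygen on an aromatic ring, putting non-aromatic carbon back on that oxygen, so a modest reversal of that step is expected, roughly a 2.0-fold lower number from compound 2 to compound 3 (0.30 log units; within the scatter). Compound 3 is accordingly estimated at 50 nM, within a range from 25 nM to 120 nM.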

Compound 3, half-maximal inhibitory concentration: 40 nM
Beside the measured number, compound 3's estimate is 1.3-fold (0.10 log units) above it; the measured number falls inside the stated range.
By their numbers in this assay, from the lowest: compounds 1 and 3 (each within the scatter of the next); then compound 2.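

In this assay the phenoxy to cyclopropyloxy change gives a 2.5-fold lower number from compound 2 to compound 3 (0.40 log units; beyond the scatter) and so shows that the step seen with phenyl is not specific to isopropyl: a second non-aromatic carbon group on this oxygen also stands apart from phenyl. Cyclopropyl and isopropyl on this oxygen cannot be told apart here, with no change at the digits printed from compound 1 to compound 3 (within the scatter) as the printed step. No supporting data bear on what lies behind these steps.

Only carbon groups appear on this oxygen so far. From the compounds shown here alone, how an aminoethyl chain or a carboxylic acid placed there would read remains open.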